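The source may hold more compounds than are shown below. What is called first, only, known or untested is meant among the compounds shown, and "the series" means these compounds.

Working notes on the series. In an assay on isolated protein for inhibition of Fatty-acid amide hydrolase 1 (Homo sapiens) (on this read-out higher numbers stand for weaker inhibition and lower numbers for stronger inhibition), compound 1 `CCCCCCCC/C=C\CCCCCCC(=O)c1nc2cccnc2o1` gives 11 nM; compound 2 `CCCCCCCC/C=C\CCCCCCC(=O)c1cccnn1` gives 130 nM; compound 3 `CCCCCCCC/C=C\CCCCCCC(=O)c1nc2ccccc2o1` gives 370 nM. Compound 3 stands highest of the three numbers, with a 2.8-fold higher number from compound 2 to compound 3 (0.45 log units; beyond the scatter) and a 34-fold higher number from compound 1 to compound 3 (1.53 log units; beyond the scatter). Compound 4 `CCCCCCCC/C=C\CCCCCCC(=O)c1nc2cnccc2o1` is not yet measured; against compound 3 the change is a group of 9 heavy atoms (6 carbon, 2 nitrogen, 1 oxygen; one five-membered aromatic ring with 2 hetero atoms, one six-membered aromatic ring with 1 hetero atom) in place of a group of 9 heavy atoms (7 carbon, 1 nitrogen, 1 oxygen; one five-membered aromatic ring with 2 hetero atoms, one six-membered aromatic ring of carbon only), on a carbonyl carbon. The step bearing on it most directly is a 34-fold higher number from compound 1 to compound 3 (1.53 log units; beyond the scatter), where the reverse exchange, a fused ring bearing one nitrogen in place of the carbon-only ring, gave a large change; a 12-fold higher number from compound 1 to compound 2 (1.07 log units; beyond the scatter) points the same way. The group entering in compound 4 is not identical to that of compound 1, so a large fall is expected, though perhaps short of the full gap. Compound 4 is expected to give 25 nM (range 6 nM to 120 nM), an expected step of a 15-fold lower number from compound 3 to compound 4 (1.17 log units; beyond the scatter).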

Compound 4, inhibition constant: 7.2 nM
The estimate for compound 4 lay 3.5-fold (0.54 log units) above the measured number; the measured number falls inside the stated range.
By their numbers in this assay, from the lowest: compounds 4 and 1 (each within the scatter of the next); then compound 2; then compound 3.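

In this assay, exchanging the carbon-only six-membered ring for one with 1 hetero atom, on the carbonyl carbon, gives a 51-fold lower number from compound 3 to compound 4 (1.71 log units; beyond the scatter), so the large shift is not confined to a single group. The two groups carrying such a ring do not separate, at a 1.5-fold lower number from compound 1 to compound 4 (0.18 log units; within the scatter), while the pyridazin-3-yl group stays well apart, at an 18-fold lower number from compound 2 to compound 4 (1.26 log units; beyond the scatter). No evidence on the cause of these steps is at hand. Still open, from the compounds shown here alone, is whether a carboxylic acid or methyl ester on the six-membered ring would hold this level, and whether it would survive a shorter chain.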